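A few compounds are considered here, and "the series" means these few. Any claim that something is new, unique, unknown or untested is made for them only; others in the source may bear on it.

Compound 2 `CCOc1ccc2nc(C(=O)Nc3c(F)cc(-c4cccc(F)c4)cc3F)c(C)c(C(=O)O)c2c1` carries an ethoxy group on an aromatic carbon of the shared core; in a functional assay on A-375 cells (Homo sapiens) for antiproliferative activity, read by MTT assay, with a stated time of 24 h, tested at 11.11 ug/mL (a higher number here means a stronger effect of the compound at the concentration tested, a lower number a weaker effect), compound 2 gives 48.3%. Compound 1 `CCc1ccc2nc(C(=O)Nc3c(F)cc(-c4cccc(F)c4)cc3F)c(C)c(C(=O)O)c2c1` differs from it in one place only, ethyl standing where compound 2 has ethoxy, and in this assay compound 1 gives 38.9%. For the measured compounds named here, the single measured step, a number 9.4 percentage points higher from compound 1 to compound 2 (within the scatter), is within the scatter, so compound 2 stands highest of the two numbers only nominally, separated from compound 1 by less than repeated runs would resolve.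

Compound 3 `COc1ccc2nc(C(=O)Nc3c(F)cc(-c4cccc(F)c4)cc3F)c(C)c(C(=O)O)c2c1` is the next member of the series: hydrogen in place of methyl on a saturated chain carbon bound to an oxygen on an aromatic ring. Going by the values given here, no measured step shortens the ethoxy group; the only step in hand, a number 9.4 percentage points higher from compound 1 to compound 2 (within the scatter), exchanges ethyl for ethoxy on an aromatic carbon and did not move the number beyond the scatter. With nothing pointing either way, removing one carbon from the ethoxy is expected to leave the read-out close to where compound 2 sits, and the step of a number 3.3 percentage points lower from compound 2 to compound 3 (within the scatter) is expected to remain within the scatter. For compound 3 the expected value in this assay is therefore 45%, with a range from 30% to 60%.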

Compound 3, a percentage reported as inhibition, at one concentration (the size of the read-out at that concentration, not a potency): 35.2%
For compound 3 the middle estimate is 9.8 percentage points above the measured one; the measured number falls inside the stated range.
By their numbers in this assay, from the lowest: compounds 3, 1 and 2 (each within the scatter of the next, the first and the last beyond it).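

For the compounds shown here, at the saturated chain carbon bound to an oxygen on an aromatic ring, ethoxy to methoxy is the first change to exceed the scatter in this assay: a number 13.1 percentage points lower from compound 2 to compound 3 (beyond the scatter). The oxygen on the aromatic carbon is therefore not enough by itself to keep the read-out near that of compound 2, since methoxy in place of ethyl gives a number 3.7 percentage points lower from compound 1 to compound 3 (within the scatter), leaving compound 3 unresolved from compound 1 even though only compound 3 shares that oxygen with compound 2. Compound 2 is separated from compound 3 but not from compound 1, so the series gives no clean order, and no available evidence accounts for the difference between ethoxy and methoxy.

On these data alone, a longer chain on the oxygen, such as propoxy or a branched isopropoxy group, would show whether the read-out continues beyond that of compound 2 or falls back, and a free hydroxyl group on the same aromatic carbon remains open as well. All three numbers come from one concentration, so they show a weaker effect at that concentration for methoxy than for ethoxy and leave open whether the same step would appear at other concentrations.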